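The source may report more compounds than this note shows. Statements on the series, on what has been measured and on what is new or still open speak of the compounds shown alone.

In a functional assay on MGC-803 cells (Homo sapiens) for antiproliferative activity, read by MTT assay, with a stated time of 48 h (a lower number here means a stronger inhibitor, a higher number a weaker inhibitor), compound 1 (`COc1ccc(CN(C(=O)CSc2nc3ccccc3s2)c2cc(OC)c(OC)c(OC)c2)cc1`) gives 163 nM, compound 2 (`COc1ccc(CN(C(=O)CSc2nc3ccccc3s2)c2cc(OC)c(OC)c(OC)c2)cc1F`) gives 416 nM and compound 3 (`COc1ccc(CN(C(=O)CSc2nc3ccccc3s2)c2cc(OC)c(OC)c(OC)c2)cc1Br`) gives 852 nM, the highest number of the three. The next entry is compound 4 (`COc1cc(N(Cc2ccc(F)cc2)C(=O)CSc2nc3ccccc3s2)cc(OC)c1OC`). The change is 4-fluorophenyl in place of 3-bromo-4-methoxyphenyl on a saturated chain carbon bound to an amide-type nitrogen, so the bromo and methoxy groups both leave and a fluoro group comes in.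

Among the measured compounds shown here, three measured steps bear on this. Fluoro in place of hydrogen gave a 2.6-fold higher number from compound 1 to compound 2 (0.41 log units; beyond the scatter), bromo in place of hydrogen gave a 5.2-fold higher number from compound 1 to compound 3 (0.72 log units; beyond the scatter), and bromo in place of fluoro gave a 2.0-fold higher number from compound 2 to compound 3 (0.31 log units; beyond the scatter). All three are modest, and each points to a lower number when bromo is lost. For the measured compounds named here, no measured compound lacks the methoxy group, so that part of the change is untested and the range stays wide.

A modest move to a lower number is expected, with the estimated change being a 2.8-fold lower number from compound 3 to compound 4 (0.45 log units; beyond the scatter). For compound 4 the estimated value is 300 nM, with an expected range of 100 nM to 850 nM.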

Compound 4, half-maximal inhibitory concentration: > 80000 nM
Compound 4: only a limit was reported; the forecaster's own chance of this, stated with the estimate: 2%; middle value at least 260-fold (2.42 log units) from the limit.
By their numbers in this assay, from the lowest: compound 1; then compound 2; then compound 3. At a limit, above all of these: compound 4.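

Compound 4 carries only a limit of the assay, not a number: the limit of > 80000 nM in this assay, at which 1 of the 4 values shown sits.

Read against that limit, the 3-bromo-4-methoxybenzyl to 4-fluorobenzyl change gives an at least 93-fold higher number from compound 3 to compound 4 (1.97 log units; beyond the scatter), the matching change from the 3-fluoro-4-methoxybenzyl group gives an at least 190-fold higher number from compound 2 to compound 4 (2.28 log units; beyond the scatter), and fluoro in place of methoxy gives an at least 490-fold higher number from compound 1 to compound 4 (2.69 log units; beyond the scatter). Among the compounds shown here, compounds 1, 2 and 3 all keep the methoxy group and showed only modest steps when a halogen was added, whereas the one compound without it shows large steps to all three, so this aromatic carbon is far less forgiving of replacing the methoxy group than the halogen steps suggested.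

The compounds shown do not separate loss of the methoxy group from arrival of the fluoro group; a plain benzyl, a 4-ethoxybenzyl or a 4-aminobenzyl group would help to do so. As far as these compounds go, the true size of all three steps also stays open.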